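Swapping a Halogen for Trifluoromethyl on the Aniline Ring

The source may hold more compounds than are shown below. What is called first, only, known or untested is meant among the compounds shown, and "the series" means these compounds.

Measured compounds:
- compound 1 `C=CC(=O)Nc1cccc(NC(=O)CSc2nc(Nc3ccccc3)c3ccccc3n2)c1`, 10200 nM
- compound 2 `C=CC(=O)Nc1cccc(NC(=O)CSc2nc(Nc3ccccc3F)c3ccccc3n2)c1`, 18700 nM
- compound 3 `C=CC(=O)Nc1cccc(NC(=O)CSc2nc(Nc3ccc(Cl)cc3)c3ccccc3n2)c1`, 10300 nM

The three compounds share one core and differ only in the group on the aniline ring. In a functional assay on MDA-MB-231 cells (Homo sapiens) for inhibition, read by MTT assay, with a stated time of 72 h (a higher number here means a weaker inhibitor, a lower number a stronger inhibitor), compound 3 gives 10300 nM, which stands second highest of the three numbers; compound 1 sits nearest, since a 1.0-fold higher number from compound 1 to compound 3 (0.00 log units; within the scatter), while compound 2 sits furthest, since a 1.8-fold lower number from compound 2 to compound 3 (0.26 log units; within the scatter). All three values therefore lie within the scatter of one another, and no ordering can be read from them.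

Compound 4 `C=CC(=O)Nc1cccc(NC(=O)CSc2nc(Nc3ccc(C(F)(F)F)cc3)c3ccccc3n2)c1` carries the change (trifluoromethyl in place of chloro on an aromatic carbon), that is trifluoromethyl in place of chloro on an aromatic carbon. Within the data shown here, no measured step tests this exact change. The steps that come closest are the addition of a halogen to the aniline ring: a 1.8-fold higher number from compound 1 to compound 2 (0.26 log units; within the scatter) and a 1.0-fold higher number from compound 1 to compound 3 (0.00 log units; within the scatter). Neither moved the number beyond the scatter, so a substituent at this ring has so far left this assay essentially unchanged.

On that basis compound 4 is expected to show a 1.2-fold higher number from compound 3 to compound 4 (0.07 log units; within the scatter), nothing beyond the scatter. The estimate for compound 4 is 12000 nM, with a range from 5000 nM to 30000 nM.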

Compound 4, half-maximal inhibitory concentration: 11500 nM
Beside the measured number, compound 4's estimate is 1.0-fold (0.02 log units) above it; the measured number falls inside the stated range.
By their numbers in this assay, from the lowest: compounds 1, 3, 4 and 2 (each within the scatter of the next).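

In this assay, putting trifluoromethyl in place of chloro on the aniline ring gives a 1.1-fold higher number from compound 3 to compound 4 (0.05 log units; within the scatter), so this place on the ring, para to a large group, accepts a group of several atoms as readily as a single chlorine, with no readable shift in the number. The comparison with hydrogen at that carbon shows a 1.1-fold higher number from compound 1 to compound 4 (0.05 log units; within the scatter), and the comparison with the 2-fluorophenyl group on the nitrogen shows a 1.6-fold lower number from compound 2 to compound 4 (0.21 log units; within the scatter). The flat picture seen with fluoro and chloro therefore extends to a group that is more than one halogen atom, and the four compounds still give no ordering.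

As far as these compounds go, whether a group of another kind on this ring, such as an amine, a carboxylic acid or a longer alkyl chain, would move the number beyond the scatter stays open, as does the effect of any change elsewhere on the shared core. Nothing measured here accounts for how close these numbers stay.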